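Compound 3 and its bromo counterpart

This account rests on a few compounds, and the source may have more. Where it says the series, first, only, none or still open, it means among the compounds named here.

In a functional assay on K562 cells (Homo sapiens) for inhibition, read by trypan blue exclusion, with a stated time of 72 h (a lower number here means a stronger inhibitor, a higher number a weaker inhibitor), compound 1 `Cn1c(=O)c(S(=O)(=O)c2ccc(C(=O)O)cc2)cc2cnc(Nc3ccc4[nH]ccc4c3)nc21` gives 5000 nM, compound 2 `COc1ccc(S(=O)(=O)c2cc3cnc(Nc4ccc5[nH]ccc5c4)nc3n(C)c2=O)cc1` gives 300 nM and compound 3 `Cn1c(=O)c(S(=O)(=O)c2ccc(Cl)cc2)cc2cnc(Nc3ccc4[nH]ccc4c3)nc21` gives 100 nM, the lowest of the three numbers. Compound 4 `Cn1c(=O)c(S(=O)(=O)c2ccc(Br)cc2)cc2cnc(Nc3ccc4[nH]ccc4c3)nc21` has bromo in place of chloro on an aromatic carbon, para to a large group (bromo in place of chloro on an aromatic carbon). The measured steps all change that same place. Two replace carboxy and are large: a 17-fold lower number from compound 1 to compound 2 (1.22 log units; beyond the scatter) and a 50-fold lower number from compound 1 to compound 3 (1.70 log units; beyond the scatter). The third, chloro in place of methoxy, is modest: a 3.0-fold lower number from compound 2 to compound 3 (0.48 log units; beyond the scatter). None involves bromo, so this is only indirect guidance, and no clear direction is expected. The expected result is no change at the digits printed from compound 3 to compound 4 (within the scatter). Compound 4 is estimated at 100 nM, with an expected range of 40 nM to 300 nM.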

Compound 4, half-maximal inhibitory concentration: 5000 nM
Compound 4: the middle estimate sits 50-fold (1.70 log units) below what was measured; measured number above the stated range.
By their numbers in this assay, from the lowest: compound 3; then compound 2; then compounds 1 and 4 (each within the scatter of the next).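

In this assay, for the compounds shown here, this position separates even two halogens: bromo in place of chloro is a large step (a 50-fold higher number from compound 3 to compound 4 (1.70 log units; beyond the scatter)), which the earlier compounds, none of them bearing bromo, could not show. Bromo also falls well behind methoxy (a 17-fold higher number from compound 2 to compound 4 (1.22 log units; beyond the scatter)) and cannot be told apart from carboxy (no change at the digits printed from compound 1 to compound 4 (within the scatter)), so the 4-chlorophenyl and 4-bromophenyl compounds do not behave alike here. Nothing available accounts for this gap between the two halogens.

Going by these compounds, whether fluoro, methyl or an amine at this place would read like chloro or like bromo remains open.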